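The source may report more compounds than this note shows. Statements on the series, on what has been measured and on what is new or still open speak of the compounds shown alone.

Measured so far in an assay on membranes from CHO cells for displacement of a labelled ligand from adenosine receptor A1 (Homo sapiens), read by scintillation counting, with a stated time of 60 min, tested at 1 uM; on this read-out lower numbers stand for less inhibition and higher numbers for more inhibition at the one concentration tested (going by the name of the read-out):
- compound 1 `CC(=O)C1=C(C)NC(=O)NC1c1ccsc1` gives 9%
- compound 2 `CC1=C(C(=O)OCC2CC2)C(c2ccoc2)NC(=O)N1` gives 29%
- compound 3 `CC1=C(C(=O)OCC2CC2)C(c2cccs2)NC(=O)N1` gives 23%

Compound 3 stands second highest of these three numbers. Its nearest neighbour is compound 2: the step of a number 6 percentage points lower from compound 2 to compound 3 (within the scatter) lies within the scatter, so the two cannot be told apart on this read-out. Among the compounds with values here, the gap from compound 1 to compound 3 is beyond the scatter, but compound 1 differs from compound 3 in more than one place, so it gives no clean step.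

Compound 4 `CC1=C(C(=O)OCC2CC2)C(c2ccsc2)NC(=O)N1` has not yet been measured. It differs from compound 3 by thiophen-3-yl in place of thiophen-2-yl on a saturated ring carbon. Within the data shown here, the one measured step that bears on this change is the one from compound 2 to compound 3, which also swapped one five-membered aromatic ring for another on the same saturated ring carbon and stayed within the scatter. Compound 1 carries the entering thiophen-3-yl group, yet with a different group on the ring atom two bonds away, so it cannot settle the question on its own.

On that basis the expected step for compound 4 is a number 1 percentage points lower from compound 3 to compound 4 (within the scatter), none beyond the scatter. Compound 4 is therefore estimated at 22%, with a range from 8% to 36%.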

Compound 4, a percentage reported as inhibition, at one concentration (the size of the read-out at that concentration, not a potency): 39%
The estimate for compound 4 lay 17 percentage points below the measured number; measured number outside the range, above it.
By their numbers in this assay, from the lowest: compound 1; then compounds 3, 2 and 4 (each within the scatter of the next, the first and the last beyond it).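

Within this assay, moving the attachment point of the thiophene ring on the saturated ring carbon, with the same atoms joined differently, gives a number 16 percentage points higher from compound 3 to compound 4 (beyond the scatter) and so shows that this change alone can exceed the scatter, which the earlier swap of one five-membered aromatic ring for another did not show. Thiophen-3-yl and furan-3-yl cannot be told apart at this position, with a number 10 percentage points higher from compound 2 to compound 4 (within the scatter) as the printed step, so the choice between sulfur and oxygen in a ring attached this way has no readable result here. With thiophen-3-yl held fixed, cyclopropylmethoxy in place of methyl on the carbonyl carbon gives a number 30 percentage points higher from compound 1 to compound 4 (beyond the scatter) and so shows that the group on the carbonyl also counts in this series.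

Still open, going by these compounds, is how other groups on the saturated ring carbon, such as phenyl or pyridyl, or a longer chain such as butoxy on the carbonyl carbon, would read in this assay. The data offer no measured explanation for why the attachment point or the carbonyl group changes the number.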